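Pentyl to pentenyl on a leukotriene receptor ligand

A few compounds are considered here, and "the series" means these few. Any claim that something is new, unique, unknown or untested is made for them only; others in the source may bear on it.

Measured so far:
Compound 1 `C=CCc1cc(C(C)=O)c(O)cc1OCCCCCCCCCCC#N` gives 50% in an assay on isolated protein for inhibition of leukotriene B4 receptor 1 (Homo sapiens), tested at 10 uM; on this read-out lower numbers stand for less inhibition and higher numbers for more inhibition at the one concentration tested (going by the name of the read-out).
Compound 2 `C=CCc1cc(C(C)=O)c(O)cc1OCCCCC` gives 60% in this assay.

Compound 2 holds the higher of the two numbers in this assay, but its gap to compound 1, a number 10 percentage points higher from compound 1 to compound 2 (within the scatter), stays inside the usual scatter, so the two are not told apart. That step removed a 5-cyanopentyl group from a saturated chain carbon and replaced it with hydrogen.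

Compound 3 `C=CCCCCOc1cc(O)c(C(C)=O)cc1CC=C` has not yet been measured. It differs from compound 2 by vinyl in place of methyl on a saturated chain carbon, four bonds along the chain from an oxygen on an aromatic ring. Among the measured compounds shown here, the one measured step, a large change in chain length, altered the number only within the scatter. For the measured compounds named here, the swap of a methyl for a vinyl group is smaller than that, and no measured pair shows this change directly, so there is no basis for expecting a step beyond the scatter in either direction.

The estimate for compound 3 in this assay is therefore 58%, within a range from 40% to 76%. The expected step of a number 2 percentage points lower from compound 2 to compound 3 (within the scatter) is essentially no change.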

Compound 3, a percentage reported as inhibition, at one concentration (the size of the read-out at that concentration, not a potency): 73%
Compound 3: the middle estimate sits 15 percentage points below what was measured; low and high end bracket the measured number.
By their numbers in this assay, from the lowest: compounds 1 and 2 (each within the scatter of the next); then compound 3.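

Among the compounds shown here, replacing methyl with vinyl on a saturated chain carbon, four bonds along the chain from an oxygen on an aromatic ring, gives the first step in this small set that clears the scatter in this assay: a number 13 percentage points higher from compound 2 to compound 3 (beyond the scatter). This position therefore responds to a change of only one extra carbon and one double bond, whereas the earlier step between compound 1 and compound 2 could not be told apart from the scatter. Replacing 6-cyanohexyl with vinyl at the same place gives a number 23 percentage points higher from compound 1 to compound 3 (beyond the scatter), so compound 3 stands clear of both other compounds and has the highest inhibition of the three in this assay, although no measured evidence here accounts for the gain.

The compounds shown do not separate the effect of the added carbon from that of the double bond, and a saturated hexyl chain in the same place would be needed to tell the two apart. As far as these compounds go, how a carboxylic acid or an amine on this chain would read in this assay also remains open.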